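Chlorine for Methyl on the Anilino Ring

This account rests on a few compounds, and the source may have more. Where it says the series, first, only, none or still open, it means among the compounds named here.

Compound 1 `COc1cc(/C=C/C(=O)c2sc(Nc3ccc(C)cc3)nc2C)cc(OC)c1OC`; in a functional assay on BGC-823 cells (Homo sapiens) for cytotoxicity, read by MTT assay (a lower number here means a stronger inhibitor, a higher number a weaker inhibitor), compound 1 gives only a limit, > 25000 nM.
Compound 2 `COc1cc(/C=C/C(=O)c2sc(Nc3cccc(C)c3)nc2C)cc(OC)c1OC`; in this assay compound 2 gives 17200 nM.
Compound 3 `COc1cccc(/C=C/C(=O)c2sc(Nc3ccccc3C)nc2C)c1`; in this assay compound 3 gives only a limit, > 25000 nM.

Compound 2 is the only one of the three with a plain number in this assay; the other two sit at the limit described by the limit of > 25000 nM in this assay, at which 2 of the 3 values shown sit. Among the compounds with values here, the one step that can be sized within this set, an at least 1.4-fold lower number from compound 1 to compound 2 (0.16 log units; that floor lies within the scatter), is small and its floor lies within the scatter, so it shows no more than that compound 2 is not weaker than compound 1.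

The compound still to be measured is compound 4 `COc1cc(/C=C/C(=O)c2sc(Nc3ccc(Cl)cc3)nc2C)cc(OC)c1OC`. It differs from compound 2 in one place: 4-chlorophenyl in place of 3-methylphenyl on a nitrogen on an aromatic ring.

Within the data shown here, the only measured step that bears on this change is the one from compound 1 to compound 2, and it is tiny. Nothing in the set shows a chlorine at this position. Given an at least 1.4-fold lower number from compound 1 to compound 2 (0.16 log units; that floor lies within the scatter), compound 4 is expected to move, if at all, back towards the weaker side, with a 1.2-fold higher number from compound 2 to compound 4 (0.07 log units; within the scatter) judged to lie within the scatter. Compound 4 is therefore estimated at 20000 nM, in the range 8000 nM to 50000 nM.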

Compound 4, half-maximal inhibitory concentration: > 25000 nM
Compound 4 ended at the assay's limit; the forecaster's own chance of this, stated with the estimate: 40%; middle value at least 1.2-fold (0.09 log units) from the limit.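

Compound 4 gives only a limit in this assay, so 4-chlorophenyl on this nitrogen yields no plain number, just as 4-methylphenyl did not in compound 1. Within the data shown here, the one readable step, an at least 1.4-fold higher number from compound 2 to compound 4 (0.16 log units; that floor lies within the scatter), has only a floor, so it shows that compound 4 is not stronger than compound 2 but establishes no real loss. The step from compound 1 to compound 4, chloro in place of methyl on an aromatic carbon, cannot be read because both compounds sit at the same limit, as most of the set does: the limit of > 25000 nM in this assay, at which 3 of the 4 values shown sit.

Compound 2 and compound 4 differ in both the group and its place on the ring, so the two effects remain unseparated. As far as these compounds go, how 3-chlorophenyl or 3-aminophenyl on this nitrogen would read stays open.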